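Methyl for hydrogen on a benzyl ring of a hydrazone

The source may hold more compounds than are shown below. What is called first, only, known or untested is meant among the compounds shown, and "the series" means these compounds.

Measured compounds:
compound 1 `Cc1ccc(Cn2ccnc2/C=N/Nc2nc(NCCN(C)C)c3ccccc3n2)cc1` — 2980 nM
compound 2 `CN(C)CCCNc1nc(N/N=C/c2nccn2Cc2ccccc2)nc2ccccc12` — 4040 nM

In a functional assay on HepG2 cells (Homo sapiens) for cytotoxicity, read by MTT assay, with a stated time of 72 h (on this read-out higher numbers stand for weaker inhibition and lower numbers for stronger inhibition), compound 2 gives 4040 nM, the highest of the two numbers, while compound 1 gives 2980 nM, a gap that lies within the scatter of the assay. Compound 3 `Cc1ccc(Cn2ccnc2/C=N/Nc2nc(NCCCN(C)C)c3ccccc3n2)cc1` is reached from compound 2 by the change (methyl in place of hydrogen on an aromatic carbon). Among the compounds with values here, with only two measured compounds and no step between them, there is no basis to expect a move beyond the scatter. The number for compound 3 in this assay is therefore estimated at 3300 nM, between 1500 nM and 7000 nM, a step of a 1.2-fold lower number from compound 2 to compound 3 (0.09 log units; within the scatter) that is expected to stay within the scatter.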

Compound 3, half-maximal inhibitory concentration: 3680 nM
Compound 3: middle estimate off by 1.1-fold (0.05 log units), on the low side; the measured number falls inside the stated range.
By their numbers in this assay, from the lowest: compounds 1, 3 and 2 (each within the scatter of the next).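

In this assay, 4-methylbenzyl in place of benzyl gives a 1.1-fold lower number from compound 2 to compound 3 (0.04 log units; within the scatter) and so leaves the number within the scatter at this position on the ring. Within the data shown here, the same 4-methylbenzyl compounds also give the first reading of the side chain, where (dimethylamino)methyl in place of dimethylamino gives a 1.2-fold higher number from compound 1 to compound 3 (0.09 log units; within the scatter) and likewise stays within the scatter. Nothing available accounts for either step.

From the compounds shown here alone, whether chlorine or methoxy at this ring position would move the number stays open. So does the effect of a morpholine or a carboxylic acid at the end of the chain.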